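Methyl in place of hydrogen on the fused core of compound 1

The compounds below may be only part of what the source reports. "The series", "measured", "known", "first", "only" and "open" are said of these compounds alone.

Compound 1 `O=C(NCCCCc1ccccc1)n1c(=O)oc2ccccc21` is the parent of this small set. In an assay on HEK293 cells for inhibition of acid ceramidase (Homo sapiens), with a stated time of 10 min (a higher number here means a weaker inhibitor, a lower number a stronger inhibitor), compound 1 gives 64 nM, which is the higher of the two numbers reported, the other belonging to compound 3 `O=C(NCCCCc1ccccc1)n1c(=O)oc2ccc([N+](=O)[O-])cc21`, which in this assay gives 3 nM. Compound 2 `Cc1cccc2oc(=O)n(C(=O)NCCCCc3ccccc3)c12`, a methyl analogue, gives no result reported in this assay. For the measured compounds named here, the one step with numbers on both sides, a 21-fold lower number from compound 1 to compound 3 (1.33 log units; beyond the scatter), shows that a substituent on the aromatic carbon of the fused core can move the number a long way. Compound 4 `Cc1ccc2c(c1)oc(=O)n2C(=O)NCCCCc1ccccc1` differs from compound 1 by methyl in place of hydrogen on an aromatic carbon. Going by the values given here, no measured step introduces a methyl group, and the nitro step of compound 3 concerns a different group, so it bears only loosely on the change. He therefore expects the step of a 1.4-fold lower number from compound 1 to compound 4 (0.15 log units; within the scatter) to be small, possibly a slight lowering, but not clearly beyond the scatter. His estimate for compound 4 in this assay is 45 nM, within a range from 15 nM to 130 nM.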

Compound 4, half-maximal inhibitory concentration: 66 nM
Compound 4: middle estimate off by 1.5-fold (0.17 log units), on the low side; measured number inside the range.
By their numbers in this assay, from the lowest: compound 3; then compounds 1 and 4 (each within the scatter of the next).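

In this assay, methyl in place of hydrogen on this aromatic carbon, meta to a fused ring and para to a fused ring, gives a 1.0-fold higher number from compound 1 to compound 4 (0.01 log units; within the scatter), so compound 4 stands within the scatter of compound 1. The earlier step, a 21-fold lower number from compound 1 to compound 3 (1.33 log units; beyond the scatter), had shown that a group on an aromatic carbon of the core can carry a large step, and this result shows that the methyl group at this place does not. No measured evidence bears on this result, so it gives a size but no explanation.

The step for compound 2, the other methyl analogue, cannot be read, so these compounds do not show how methyl behaves elsewhere on the core. They also leave open whether nitro, an amine or a methoxy group at the carbon carrying methyl in compound 4 would give a step beyond the scatter.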